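A Dimethylphenyl Variant Against Three Unreadable Limits

The source may report more compounds than this note shows. Statements on the series, on what has been measured and on what is new or still open speak of the compounds shown alone.

Compound 2 `CN(c1cccc2c1CN(c1nc(Nc3ccc(Cl)c(C(F)(F)F)c3)ncc1C(F)(F)F)C2)S(C)(=O)=O` is the starting point. In an assay on Sf9 cells for inhibition of tyrosine-protein kinase receptor UFO (Homo sapiens), read by luminescence and ADP-Glo (a higher number here means a weaker inhibitor, a lower number a stronger inhibitor), compound 2 gives > 20000 nM, which is a limit of the assay and not a number. The other two measured compounds are reported in the same way. Compound 1 `Cc1cc(Cl)ccc1Nc1ncc(C(F)(F)F)c(N2Cc3cccc(N(C)S(C)(=O)=O)c3C2)n1` gives > 20000 nM in this assay, again a limit. Compound 3 `COc1ccc(C(F)(F)F)cc1Nc1ncc(C(F)(F)F)c(N2Cc3cccc(N(C)S(C)(=O)=O)c3C2)n1` gives > 20000 nM in this assay, also a limit. Because all three sit at the limit of > 20000 nM in this assay, at which 3 of the 3 values shown sit, the three steps joining them are a step that the two limits leave unreadable from compound 1 to compound 2, a step that the two limits leave unreadable from compound 1 to compound 3 and a step that the two limits leave unreadable from compound 2 to compound 3, and none of them can be read as a size or a direction. Compound 4 `Cc1ccc(Nc2ncc(C(F)(F)F)c(N3Cc4cccc(N(C)S(C)(=O)=O)c4C3)n2)cc1C` is the unmeasured member of the set. It differs from compound 2 by 3,4-dimethylphenyl in place of 4-chloro-3-(trifluoromethyl)phenyl on a nitrogen on an aromatic ring. For the measured compounds named here, the steps that bear on this change are the three unreadable ones, so they supply neither a size nor a direction; what they do show is that three different groups on that nitrogen all leave the value at the limit. Compound 4 is therefore expected to stay there as well, with a step of a number no higher from compound 2 to compound 4 (the limit leaves the size open) that is expected to be nothing beyond the scatter. Compound 4 is estimated at 20000 nM in this assay, in the range 5000 nM to 100000 nM.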

Compound 4, half-maximal inhibitory concentration: > 20000 nM
Compound 4: only a limit was reported; the forecaster's own chance of this, stated with the estimate: 80%; the middle value lies on the limit itself.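

In this assay compound 4 gives > 20000 nM which is a limit of the assay and not a number. For the compounds shown here, no new step from compound 1, compound 2 or compound 3 to compound 4 can be read, in size or direction, because all four compounds share one limit: the limit of > 20000 nM in this assay, at which 4 of the 4 values shown sit. The compounds shown leave open whether any group on that nitrogen gives a measurable value.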